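The source may hold more compounds than are shown below. What is called first, only, known or untested is meant among the compounds shown, and "the series" means these compounds.

Notes on the series. In a functional assay on HepG2 cells (Homo sapiens) for antiproliferative activity, read by MTT assay, with a stated time of 48 h (on this read-out higher numbers stand for weaker inhibition and lower numbers for stronger inhibition), compound 1 `N#CC1=C(N)Oc2c(c3nc4ccccc4nc3c3ccccc23)C12C(=O)N(Cc1cnnn1-c1ccc(Cl)cc1)c1ccccc12` returns no number but a limit, > 50000 nM. For the measured compounds named here, compound 2 `N#CC1=C(N)Oc2c(N)cc3nc4ccccc4nc3c2C12C(=O)N(Cc1cnnn1-c1ccccc1Br)c1ccccc12` gives 38000 nM in this assay and is the only compound in the set read as a number. The other entry stands at the limit of > 50000 nM in this assay, at which 1 of the 2 values shown sits. Going by the values given here, compound 1 and compound 2 differ in more than one place, so their two values say only that compound 2 is read as a number where compound 1 is not.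

The open question is compound 3 `N#CC1=C(N)Oc2c(N)cc3nc4ccccc4nc3c2C12C(=O)N(Cc1cnnn1-c1cc(Cl)ccc1Cl)c1ccccc12`, not yet run in this assay. Its change from compound 2 is 2,5-dichlorophenyl in place of 2-bromophenyl on an aromatic nitrogen. Among the compounds with values here, no step between measured compounds bears on this change, so the size of the step in this assay cannot be taken from the data; the expectation is for no shift beyond the usual scatter, in either direction. The step is estimated as a 1.1-fold higher number from compound 2 to compound 3 (0.02 log units; within the scatter). Compound 3 is estimated at 40000 nM, within 15000 nM to 100000 nM, and there is a fair chance that the assay again reports only a limit.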

Compound 3, half-maximal inhibitory concentration: 33100 nM
Compound 3: the middle estimate sits 1.2-fold (0.08 log units) above what was measured; the measured number falls inside the stated range.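

For the compounds shown here, the first step that can be read at this position, on an aromatic nitrogen of the five-membered aromatic ring with 3 nitrogen, is a 1.1-fold lower number from compound 2 to compound 3 (0.06 log units; within the scatter) in this assay. For this one pair, 2,5-dichlorophenyl in place of 2-bromophenyl brings no shift that can be told from the scatter, so the exchange of one bromine for two chlorine atoms on the phenyl ring leaves the read-out where it was, and the series now holds two values read as numbers rather than one. Nothing measured here bears on why the two aryl groups read alike.

Whether a phenyl ring with no halogen, or one carrying an amine or a carboxylic acid, would move the number at this position stays open, since the only groups shown here on the shared core carry chlorine or bromine. Compound 1 differs from the other two in more than one place, so no step to it can be read, and it stands as a limit and not a number: the limit of > 50000 nM in this assay, at which 1 of the 3 values shown sits.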